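The compounds below may be only part of what the source reports. "The series", "measured", "known", "first", "only" and "open" are said of these compounds alone.

Measured compounds:
compound 1 `Brc1cccc(/N=N/N2CCCCC2)c1`: 85000 nM
compound 2 `Cc1c(/N=N/c2cccc(C(F)(F)F)c2)ccc(NC[C@@H]2CCCN3CCCC[C@H]23)c1C`: 80000 nM
compound 3 `CN(/N=N/c1ccccc1)c1ccccc1`: 50000 nM

In an ADME assay on Vero cells (Chlorocebus sabaeus) for cytotoxicity, read by crystal violet staining (a lower number here means that less compound is tolerated, a higher number that more compound is tolerated), compound 2 gives 80000 nM, the second highest of the three numbers; compound 1 is its nearest neighbour and compound 3 the furthest, yet both lie within the scatter of compound 2, so the three values are not separable. Compound 4 `Cc1c(/N=N/c2ccccc2)ccc(NC[C@@H]2CCCN3CCCC[C@H]23)c1C` differs from compound 2 in one place: hydrogen in place of trifluoromethyl on an aromatic carbon. Going by the values given here, no pair of measured compounds shows this change, so nothing here speaks for a step in either direction; the expectation for this assay is a step from compound 2 to compound 4 of no change at the digits printed from compound 2 to compound 4 (within the scatter), that is none beyond the scatter. Compound 4 is therefore expected to give about 80000 nM, within a range from 40000 nM to 160000 nM.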

Compound 4, half-maximal cytotoxic concentration: 60000 nM
Beside the measured number, compound 4's estimate is 1.3-fold (0.12 log units) above it; the measured number falls inside the stated range.
By their numbers in this assay, from the lowest: compounds 3, 4, 2 and 1 (each within the scatter of the next).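

Going by these compounds alone, compound 2 and compound 4 form the first pair here that differs in one place, and in this assay hydrogen in place of trifluoromethyl on this aromatic carbon gives a 1.3-fold lower number from compound 2 to compound 4 (0.12 log units; within the scatter). This assay therefore does not separate the 3-(trifluoromethyl)phenyl and phenyl forms on this shared core, a comparison that compounds 1, 2 and 3 could not offer. No available evidence bears on this result. As far as these compounds go, whether an amine, a carboxylic acid or a methoxy group on this carbon would separate from hydrogen remains open. So does whether the same exchange would read alike on another core.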